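This account rests on a few compounds, and the source may have more. Where it says the series, first, only, none or still open, it means among the compounds named here.

Measured so far:
- compound 1 `COC(=O)/C=C/c1cccc(N(Cc2ccc(/C=C/c3c(Cl)cccc3Cl)cc2)C(=O)C(C)C)c1`: 195 nM in an assay on isolated protein with Bile acid receptor (Homo sapiens) as the target; on this read-out higher numbers stand for an effect only at larger amounts of compound and lower numbers for an effect already at smaller amounts
- compound 2 `COC(=O)/C=C/c1cccc(N(Cc2ccc(/C=C/c3cc(C(F)(F)F)cc(C(F)(F)F)c3)cc2)C(=O)C2CCCCC2)c1`: 1470 nM in this assay

Compound 1 holds the lowest of the two numbers; compound 2 sits at a higher number, and the gap between the two lies beyond the scatter. The two differ in more than one place, so nothing is read from them as a single step.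

Compound 3 `COC(=O)/C=C/c1cccc(N(Cc2ccc(/C=C/c3ccccn3)cc2)C(=O)C(C)C)c1` is not yet measured. It keeps the core of compound 1 and changes only one place: pyridin-2-yl in place of 2,6-dichlorophenyl on a double-bonded chain carbon bound to a double-bonded chain carbon. Going by the values given here, no measured pair isolates this change, so the expectation rests only on the value of compound 1 in this assay and on the size of the group that leaves. For compound 3 the step of a 7.7-fold higher number from compound 1 to compound 3 (0.89 log units; beyond the scatter) is expected to go toward a higher number, beyond the scatter. Compound 3 is thus estimated at 1500 nM, with a range from 400 nM to 6000 nM.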

Compound 3, half-maximal effective concentration: 310 nM
Estimate against measurement, compound 3: 4.8-fold (0.68 log units) above; measured number outside the range, below it.
By their numbers in this assay, from the lowest: compounds 1 and 3 (each within the scatter of the next); then compound 2.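

In this assay, pyridin-2-yl in place of 2,6-dichlorophenyl on a double-bonded chain carbon bound to a double-bonded chain carbon gives a 1.6-fold higher number from compound 1 to compound 3 (0.20 log units; within the scatter). This position therefore accepts both a carbon-only aromatic ring carrying two chlorine atoms and a six-membered aromatic ring with one hetero atom and one hydrogen-bond acceptor, with no separation between compound 1 and compound 3 on this read-out, even though the entering group has fewer heavy atoms. No measured evidence accounts for this equivalence.

The compounds shown leave open whether a plain phenyl group at this place would also fall within the scatter of compound 1 and compound 3, which would test the chlorine atoms and the ring nitrogen apart from each other. Also open, going by these compounds, is whether the equivalence holds with a carboxylic acid in place of the methyl ester.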